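The compounds below may be only part of what the source reports. "The series", "measured", "known", "first", "only" and "open" are said of these compounds alone.

Measured compounds:
compound 1 `Cc1cccc(NC(=O)CSC(=S)N[C@H]2CCOC2=O)c1`: > 128000 nM
compound 2 `O=C(CCl)Nc1ccc(C(=O)/C=C/c2ccc(Br)cc2)cc1`: 13300 nM

Of the compounds shown here, two have been tested in a functional assay on SMMC-7721 cells (Homo sapiens) for cytotoxicity, read by MTT assay, with a stated time of 72 h; on this read-out higher numbers stand for weaker inhibition and lower numbers for stronger inhibition. For compound 1 the reported value is a limit of the assay and not a number: in this assay compound 1 gives > 128000 nM. For the measured compounds named here, compound 2 gives 13300 nM in this assay and is the only compound with a number rather than a limit, so it stands alone among the measured values, with nothing to rank it against.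

Compound 3 `Cc1ccc(/C=C/C(=O)c2ccc(NC(=O)CCl)cc2)cc1` has not yet been measured. It differs from compound 2 by methyl in place of bromo on an aromatic carbon. Going by the values given here, no pair of measured compounds differs at this position, so the size of the step rests on the change alone. The step from compound 2 to compound 3 is expected to stay within the scatter of repeated measurements, with no clear direction: a 1.1-fold higher number from compound 2 to compound 3 (0.05 log units; within the scatter). For compound 3 the estimated value in this assay is 15000 nM, between 5000 nM and 45000 nM.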

Compound 3, half-maximal inhibitory concentration: 22900 nM
Estimate against measurement, compound 3: 1.5-fold (0.18 log units) below; the range from low to high includes it.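

In this assay, for the compounds shown here, the change from 4-bromophenyl to 4-methylphenyl gives a 1.7-fold higher number from compound 2 to compound 3 (0.24 log units; within the scatter), the first step that can be read at this position. On the shared core, with the group para to a large group, this assay therefore does not tell methyl and bromo apart, and neither group can be ranked over the other. Nothing shown gives a reason for this step.

As far as these compounds go, whether an amine or a carboxylic acid on the same aromatic carbon would give a step beyond the scatter remains open. From the compounds shown here alone, it also remains open whether a change elsewhere on the shared core would weigh more in this assay than the exchange of these two groups.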